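Dichlorophenyl in Place of Aminophenyl at the Carbonyl

The source may report more compounds than this note shows. Statements on the series, on what has been measured and on what is new or still open speak of the compounds shown alone.

Compound 1 `COc1cc(-c2cc(/C=C/C(=O)c3ccc(N)cc3)[nH]n2)cc(OC)c1OC` was tested in a functional assay on NCI-H226 cells (Homo sapiens) for cytotoxicity, read by sulforhodamine B assay, with a stated time of 48 h, tested at 0.1 uM (on this read-out higher numbers stand for a weaker effect at the one concentration tested and lower numbers for a stronger effect), where compound 1 gives 98%, the highest of the two numbers recorded. Within the data shown here, its only neighbour is compound 2 `COc1ccc(-c2cc(/C=C/C(=O)c3ccc(OC)c(OC)c3)[nH]n2)cc1`, which in this assay gives 90%, a gap within the usual scatter, so the two cannot be ordered. Compound 3 `COc1cc(-c2cc(/C=C/C(=O)c3ccc(Cl)c(Cl)c3)[nH]n2)cc(OC)c1OC` carries 3,4-dichlorophenyl in place of 4-aminophenyl on a carbonyl carbon. Among the measured compounds shown here, no measured pair shows this change. Because compound 1 already sits at 98%, the step expected in this assay is a number 4 percentage points lower from compound 1 to compound 3 (within the scatter), not beyond the scatter. The estimate for compound 3 in this assay is 94%, ranging from 82% to 103%.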

Compound 3, a percentage reported as activity, at one concentration (the size of the read-out at that concentration, not a potency): 103%
Compound 3: middle estimate off by 9 percentage points, on the low side; measured number inside the range.
By their numbers in this assay, from the lowest: compounds 2, 1 and 3 (each within the scatter of the next, the first and the last beyond it).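

Placing 3,4-dichlorophenyl in place of 4-aminophenyl on a carbonyl carbon gives, in this assay, a number 5 percentage points higher from compound 1 to compound 3 (within the scatter). Among these compounds, this is the first single-place comparison at this position, and it does not separate compound 3 from compound 1, even though the hydrogen-bond donor and acceptor of the 4-aminophenyl group are gone. Nothing available explains this result. From the compounds shown here alone, whether a 4-carboxyphenyl or a morpholine at this carbonyl carbon would give a step beyond the scatter remains open. So does whether compound 1 and compound 3 differ at any other concentration.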